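The compounds below may be only part of what the source reports. "The series", "measured", "known", "first", "only" and "open" are said of these compounds alone.

In a functional assay on HCT-116 cells (Homo sapiens) for cytotoxicity, read by sulforhodamine B assay, with a stated time of 48 h, tested at 0.01 uM (a lower number here means a stronger effect, a higher number a weaker effect of the compound at the concentration tested), three compounds have been measured so far:

compound 1 `COc1cc(-c2cc(/C=C/C(=O)c3ccc(N)cc3)[nH]n2)cc(OC)c1OC` gives 95%
compound 2 `COc1ccc(-c2cc(/C=C/C(=O)c3ccc(N)cc3)[nH]n2)cc1` gives 97%
compound 3 `COc1ccc(C(=O)/C=C/c2cc(-c3cc(OC)c(OC)c(OC)c3)n[nH]2)cc1` gives 100%

All three numbers sit near the top of the scale, which means that at the concentration tested none of them produces much of an effect. On the numbers shown, the value of compound 3 in this assay lies close to that of compound 2 and a little further from that of compound 1, but both gaps fall within the scatter, so the three compounds cannot be placed in any order. Going by the values given here, the one measured step that alters the same part of the molecule is a number 5 percentage points higher from compound 1 to compound 3 (within the scatter), and it too stays within the scatter.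

Compound 4 `COc1cc(-c2cc(/C=C/C(=O)c3ccc(F)c(F)c3)[nH]n2)cc(OC)c1OC` differs from compound 3 in one place: 3,4-difluorophenyl in place of 4-methoxyphenyl on a carbonyl carbon. Among the compounds with values here, this is once more an exchange of the aryl group on the carbonyl carbon, the region where the single measured step showed no movement beyond the scatter. Within the data shown here, no measured pair swaps a methoxy-bearing aryl for a fluorine-bearing one, so the expectation rests on that one step alone. Compound 4 is therefore expected to change little: a number 5 percentage points lower from compound 3 to compound 4 (within the scatter). The estimate for compound 4 in this assay is 95%, within a range of 80% to 102%.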

Compound 4, a percentage reported as activity, at one concentration (the size of the read-out at that concentration, not a potency): 101%
The estimate for compound 4 lay 6 percentage points below the measured number; the measured number falls inside the stated range.
By their numbers in this assay, from the lowest: compounds 1, 2, 3 and 4 (each within the scatter of the next).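

In this assay, the exchange on the carbonyl carbon now reaches a fluorinated aryl group: 3,4-difluorophenyl in place of 4-methoxyphenyl gives a number 1 percentage points higher from compound 3 to compound 4 (within the scatter), and 3,4-difluorophenyl in place of 4-aminophenyl gives a number 6 percentage points higher from compound 1 to compound 4 (within the scatter). Three different aryl groups have thus been compared at this one place, on a carbonyl carbon whose other neighbour is the double-bonded chain carbon, and the step to 3,4-difluorophenyl, which swaps a group counted with a hydrogen-bond acceptor for one counted without, leaves the read-out within the scatter in both comparisons. Nothing available explains why these numbers stay together.

Going by these compounds, whether a non-aromatic group on the carbonyl carbon, such as a cyclohexyl ring or a short alkyl chain, or an aryl group bearing a carboxylic acid, would move the number beyond the scatter remains open. Also open, on these data alone, is whether these aryl groups would separate at any concentration other than the single one used here.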